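Anilide variation on the hydroxy core: notes toward compound 4

A few compounds are considered here, and "the series" means these few. Any claim that something is new, unique, unknown or untested is made for them only; others in the source may bear on it.

Measured so far:
compound 1 `CCOC1=C(/C(C)=N/OCC(=O)Nc2ccc(C(F)(F)F)cc2)N(C)S(=O)(=O)c2ccccc21` — 16700 nM
compound 2 `C/C(=N\OCC(=O)Nc1ccccc1)C1=C(O)c2ccccc2S(=O)(=O)N1C` — limit > 20000 nM
compound 3 `COc1cccc(NC(=O)CO/N=C(\C)C2=C(O)c3ccccc3S(=O)(=O)N2C)c1` — limit > 20000 nM

In a functional assay on THP-1 cells (Homo sapiens) for inhibition, read by ELISA, with stated times of 2 h and 48 h (on this read-out lower numbers stand for stronger inhibition and higher numbers for weaker inhibition), compound 1 gives 16700 nM. For compound 2 the assay reports only a limit, > 20000 nM. For compound 3 likewise only a limit is reported, > 20000 nM. The step that the two limits leave unreadable from compound 2 to compound 3 is therefore not readable, as the limit of > 20000 nM in this assay, at which 2 of the 3 values shown sit, shows. Compound 3 thus stands at the limit, with no number of its own.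

Compound 4 `C/C(=N\OCC(=O)Nc1ccc(C(F)(F)F)cc1)C1=C(O)c2ccccc2S(=O)(=O)N1C` differs from compound 3 by 4-(trifluoromethyl)phenyl in place of 3-methoxyphenyl on an amide-type nitrogen. Among the compounds with values here, no measured step bears directly on this change; compound 1 carries the same anilide on another core and gives 16700 nM. Compound 4 is expected near the limit, with the step that the limit leaves unreadable from compound 3 to compound 4 not expected to be readable, estimated at 22000 nM (range 10000 nM to 50000 nM).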

Compound 4, half-maximal inhibitory concentration: > 20000 nM
Compound 4: a limit, no number (the forecaster's own chance of this, stated with the estimate: 60%); the middle value does not contradict the limit.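

In this assay compound 4 also sits at a limit, so 4-(trifluoromethyl)phenyl on the amide-type nitrogen gives the hydroxy core no number, and the steps linking compound 2, compound 3 and compound 4 cannot be read: the limit of > 20000 nM in this assay, at which 3 of the 4 values shown sit.
With the same anilide held, hydrogen in place of ethyl on an oxygen on an unsaturated carbon gives an at least 1.1-fold higher number from compound 1 to compound 4 (0.07 log units; that floor lies within the scatter), so that floor does not show the ethyl group to matter.

Still open, as far as these compounds go, is whether any anilide on the hydroxy core gives a number in this assay. Also open, from the compounds shown here alone, is how an amine or a carboxylic acid on the anilide ring would read.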